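Tolerance in MT4 cells across a set of biaryl pyrimidine anilines

The compounds below may be only part of what the source reports. "The series", "measured", "known", "first", "only" and "open" are said of these compounds alone.

Compound 1 `Cc1cc(-c2cccc(C(F)(F)F)c2)cc(C)c1Nc1ccnc(Nc2ccc(C#N)cc2)n1` gives 4030 nM in an ADME assay on MT4 cells (Homo sapiens) for cytotoxicity, read by MTT assay, with a stated time of 4 days; a higher number here means that more compound is tolerated, a lower number that less compound is tolerated. Compound 2 `COc1ccccc1-c1cc(C)c(Nc2ccnc(Nc3ccc(C#N)cc3)n2)c(C)c1` gives 940 nM in this assay. Compound 3 `Cc1cc(C)cc(-c2cc(C)c(Nc3ccnc(Nc4ccc(C#N)cc4)n3)c(C)c2)c1` gives 4140 nM in this assay.

Compound 3 stands highest of the three, although its separation from compound 1 is within the scatter, as the step of a 1.0-fold higher number from compound 1 to compound 3 (0.01 log units; within the scatter) shows, while the step of a 4.4-fold higher number from compound 2 to compound 3 (0.64 log units; beyond the scatter) puts it clearly apart from compound 2. The unmeasured compound 4 `Cc1cc(-c2ccccc2F)cc(C)c1Nc1ccnc(Nc2ccc(C#N)cc2)n1` is reached from compound 3 by the change (2-fluorophenyl in place of 3,5-dimethylphenyl on an aromatic carbon).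

For the measured compounds named here, two measured steps bear on this. Going by the values given here, the step of a 4.3-fold lower number from compound 1 to compound 2 (0.63 log units; beyond the scatter) and the step of a 4.4-fold higher number from compound 2 to compound 3 (0.64 log units; beyond the scatter) both show that the only analogue carrying a 2-methoxyphenyl, compound 2, is tolerated less than its 3-(trifluoromethyl)phenyl and 3,5-dimethylphenyl partners. Among the compounds with values here, compound 4 carries a 2-fluorophenyl, the closest kin of that 2-methoxyphenyl among the groups seen here, but fluorine and methoxy are not the same substituent and only one such example exists. A modest move toward the value of compound 2 is therefore the expected outcome, without reaching it.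

Compound 4 is expected to give about 2000 nM in this assay, between 700 nM and 6000 nM, which corresponds to an expected step of a 2.1-fold lower number from compound 3 to compound 4 (0.32 log units; beyond the scatter).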

Compound 4, half-maximal cytotoxic concentration: 2120 nM
Beside the measured number, compound 4's estimate is 1.1-fold (0.03 log units) below it, within the range that was stated.
By their numbers in this assay, from the lowest: compound 2; then compounds 4, 1 and 3 (each within the scatter of the next).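

In this assay, the 2-fluorophenyl group of compound 4 cannot be told apart from the two larger aryl groups at this position: a 2.0-fold lower number from compound 3 to compound 4 (0.29 log units; within the scatter) and a 1.9-fold lower number from compound 1 to compound 4 (0.28 log units; within the scatter) both stay within the usual scatter of repeat measurements. The exchange of fluoro for methoxy does separate two compounds, however, with a 2.3-fold higher number from compound 2 to compound 4 (0.35 log units; beyond the scatter), so the low number of compound 2 is not shared by both of the aryl groups here that carry a substituent at the 2-position of the phenyl ring, and it now appears tied to the methoxy group in particular, though it still rests on that single compound. Nothing at hand accounts for this difference between fluoro and methoxy.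

The compounds shown leave open whether the place of the fluoro on the phenyl ring matters, since 3-fluorophenyl and 4-fluorophenyl groups do not appear among them. They also leave open how tolerance would respond to a phenyl ring bearing an amine or a carboxylic acid, or to a longer chain such as a 2-ethoxyphenyl group in place of the 2-methoxyphenyl.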